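Swapping methylsulfanyl on a rapidly cleared compound

The compounds below may be only part of what the source reports. "The series", "measured", "known", "first", "only" and "open" are said of these compounds alone.

Compound 1 `CNc1nc(NC2(C#N)CCCCC2)nc(N(C)C)n1`: 276 mL/min/kg
Compound 2 `CNc1nc(NC2(C#N)CCCCC2)nc(OC)n1`: 196 mL/min/kg
Compound 3 `CNc1nc(NC2(C#N)CCCCC2)nc(SC)n1`: 579 mL/min/kg

In an ADME assay on microsomes from liver (Rattus norvegicus) for metabolic stability (on this read-out lower numbers stand for slow clearance and higher numbers for fast clearance), compound 3 gives the highest of these numbers, at 579 mL/min/kg. Compound 4 `CNc1nc(NC2(C#N)CCCCC2)nc(-n2cnc(C#N)n2)n1` has 3-cyano-1H-1,2,4-triazol-1-yl in place of methylsulfanyl on an aromatic carbon. For the measured compounds named here, two measured steps bear on this change, since both bring in the methylsulfanyl group that compound 4 gives up. These are a 2.1-fold higher number from compound 1 to compound 3 (0.32 log units; beyond the scatter) and a 3.0-fold higher number from compound 2 to compound 3 (0.47 log units; beyond the scatter), both modest. Going by the values given here, no measured compound carries the new group, so the guide is only partial. A modest fall is expected, a 2.2-fold lower number from compound 3 to compound 4 (0.35 log units; beyond the scatter). For compound 4 the estimated value is 260 mL/min/kg, with an expected range of 100 mL/min/kg to 550 mL/min/kg.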

Compound 4, clearance: 210 mL/min/kg
Estimate against measurement, compound 4: 1.2-fold (0.09 log units) above; low and high end bracket the measured number.
By their numbers in this assay, from the lowest: compounds 2, 4 and 1 (each within the scatter of the next); then compound 3.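

Replacing methylsulfanyl with 3-cyano-1H-1,2,4-triazol-1-yl gives a 2.8-fold lower number from compound 3 to compound 4 (0.44 log units; beyond the scatter) in this assay, so a five-membered aromatic ring at this position does not carry the high clearance of compound 3. The other two steps, a 1.1-fold higher number from compound 2 to compound 4 (0.03 log units; within the scatter) and a 1.3-fold lower number from compound 1 to compound 4 (0.12 log units; within the scatter), lie within the scatter, which leaves methylsulfanyl alone at the high end among these four groups. Nothing available explains this difference. On these data alone, whether a triazole without the nitrile, or a primary amine, would give a similar number remains open.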